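This account rests on a few compounds, and the source may have more. Where it says the series, first, only, none or still open, it means among the compounds named here.

Going by the values given here, the three compounds measured so far share one core and differ at a single aromatic carbon. Compound 1 `Cc1ccc(C2=NN(c3nc(-c4ccccc4)cs3)C(c3ccc(F)cc3)C2)s1` carries hydrogen there. In an ADME assay on NIH3T3 cells (Mus musculus) for cytotoxicity, read by XTT assay, with a stated time of 24 h (on this read-out lower numbers stand for stronger inhibition and higher numbers for weaker inhibition), compound 1 reaches only a limit of the assay, > 500 ug/mL. Compound 2 `Cc1ccc(C2=NN(c3nc(-c4ccc(S(C)(=O)=O)cc4)cs3)C(c3ccc(F)cc3)C2)s1` carries methylsulfonyl on that aromatic carbon, and in this assay compound 2 gives 374 ug/mL. Compound 3 `Cc1ccc(C2=NN(c3nc(-c4ccc(C(F)(F)F)cc4)cs3)C(c3ccc(F)cc3)C2)s1` carries trifluoromethyl, and in this assay compound 3 again reaches only a limit, > 500 ug/mL. Compound 3 thus stands at the upper edge of what has been measured: the limit of > 500 ug/mL in this assay, at which 2 of the 3 values shown sit, so its number cannot be placed against that of compound 1. The measured steps are all small or unreadable: an at least 1.3-fold lower number from compound 1 to compound 2 (0.12 log units; that floor lies within the scatter), an at least 1.3-fold higher number from compound 2 to compound 3 (0.12 log units; that floor lies within the scatter) and a step that the two limits leave unreadable from compound 1 to compound 3.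

Compound 4 `COc1ccc(-c2csc(N3N=C(c4ccc(C)s4)CC3c3ccc(F)cc3)n2)cc1` differs from compound 3 by methoxy in place of trifluoromethyl on an aromatic carbon. Among the compounds with values here, no measured step involves methoxy, so only the three steps just given, which are within the scatter or unreadable, bear on this change. With every exchange at that aromatic carbon having left this assay at or near its limit, a step of no size beyond the scatter is expected, a number no higher from compound 3 to compound 4 (the limit leaves the size open). Compound 4 is accordingly estimated at 500 ug/mL, within a range from 300 ug/mL to 800 ug/mL, and most likely reported once more as a limit.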

Compound 4, half-maximal inhibitory concentration: 147 ug/mL
Compound 4: the middle estimate sits 3.4-fold (0.53 log units) above what was measured; measured number below the stated range.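

In this assay, this aromatic carbon can move the number beyond the scatter, which no earlier exchange had shown: methoxy in place of trifluoromethyl gives an at least 3.4-fold lower number from compound 3 to compound 4 (0.53 log units; beyond the scatter), and methoxy in place of hydrogen gives an at least 3.4-fold lower number from compound 1 to compound 4 (0.53 log units; beyond the scatter). Against methylsulfonyl, the only other group here with a number rather than a limit, the exchange gives a 2.5-fold lower number from compound 2 to compound 4 (0.41 log units; beyond the scatter), so compound 4 has the lowest number of the four, with its steps to all the others printed as beyond the scatter. Compound 1 and compound 3 remain limits and not numbers, so only a floor can be read for the two steps that start from them: the limit of > 500 ug/mL in this assay, at which 2 of the 4 values shown sit.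

The compounds shown leave open whether the lower number stays with methoxy alone or also comes with a hydroxyl, an amine or a longer chain such as ethoxy on that aromatic carbon. They also leave open whether methoxy at this place would give a lower number with other groups elsewhere on the shared core.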